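Piperidine nitrogen substituent: sulfonyl to cyclic amidine

The compounds below may be only part of what the source reports. "The series", "measured", "known", "first", "only" and "open" are said of these compounds alone.

Compound 3 `CC(C)S(=O)(=O)N1CCC(Oc2ncnc3c2CCN3c2ccc(S(C)(=O)=O)cc2F)CC1` stands highest of the three measured compounds in a functional assay on CHO-K1 cells for agonist activity at Glucose-dependent insulinotropic receptor (Homo sapiens), read by a luciferase reporter, with a stated time of 5 h (a higher number here means that more compound is needed for the effect, a lower number that less compound is needed), where compound 3 gives 1260 nM. Its nearest neighbour is compound 2 `CS(=O)(=O)c1ccc(N2CCc3c(OC4CCN(C(=O)OCCF)CC4)ncnc32)c(F)c1`, which in this assay gives 501 nM; the furthest is compound 1 `CCCOC(=O)N1CCC(Oc2ncnc3c2CCN3c2ccc(S(C)(=O)=O)cc2F)CC1`, which in this assay gives 79.4 nM.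

The step to compound 4 `CS(=O)(=O)c1ccc(N2CCc3c(OC4CCN(C5=NCCCN5)CC4)ncnc32)c(F)c1` is a group of 6 heavy atoms (4 carbon, 2 nitrogen; one six-membered non-aromatic ring with 2 hetero atoms) in place of a group of 6 heavy atoms (3 carbon, 2 oxygen, 1 sulfur; no ring), on an amine nitrogen in a ring. Two measured steps alter the same amine nitrogen in a ring: a 16-fold higher number from compound 1 to compound 3 (1.20 log units; beyond the scatter) and a 2.5-fold higher number from compound 2 to compound 3 (0.40 log units; beyond the scatter). Both show that the group on this nitrogen moves the number well beyond the scatter, and in both the isopropylsulfonyl of compound 3 sits at the high end. The step of a 6.3-fold higher number from compound 1 to compound 2 (0.80 log units; beyond the scatter) concerns only the chain of the carbamate and does not touch the change in hand. For the measured compounds named here, no measured compound carries a cyclic amidine at this position, so the direction of the step rests on the observation that each replacement of the isopropylsulfonyl so far gave a lower number.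

For compound 4 a lower number than compound 3 is therefore expected, with the step estimated as a 2.0-fold lower number from compound 3 to compound 4 (0.30 log units; within the scatter). Going by the values given here, the estimate for compound 4 in this assay is 630 nM, within a range from 160 nM to 2500 nM; a wide range is kept because the new group has no measured counterpart.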

Compound 4, half-maximal effective concentration: 2000 nM
Estimate against measurement, compound 4: 3.2-fold (0.50 log units) below, and the stated range covers the measured number.
By their numbers in this assay, from the lowest: compound 1; then compound 2; then compounds 3 and 4 (each within the scatter of the next).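

In this assay, the group with the six-membered non-aromatic ring and the isopropylsulfonyl on this amine nitrogen are not separated (a 1.6-fold higher number from compound 3 to compound 4 (0.20 log units; within the scatter)), although the entering group brings a hydrogen-bond donor and a ring that the isopropylsulfonyl lacks. The carbamates now stand apart from both non-carbamate groups, as seen in a 4.0-fold higher number from compound 2 to compound 4 (0.60 log units; beyond the scatter) and in a 25-fold higher number from compound 1 to compound 4 (1.40 log units; beyond the scatter), and among these four compounds none goes against this split, so the isopropylsulfonyl of compound 3 no longer marks a high end that any replacement would improve on. No data in hand bear on why the two non-carbamate groups read alike here.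

Still open, going by these compounds, is whether the split follows the carbamate itself, which a urea or an acetyl group on the same nitrogen would help to test, and whether a five-membered cyclic amidine or a smaller methylsulfonyl would sit with compound 3 and compound 4. Also open, on these data alone, is how far the carbamate chain can vary beyond propoxycarbonyl and (2-fluoroethoxy)carbonyl, for example with isopropoxycarbonyl or a longer butoxycarbonyl chain.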